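The source may report more compounds than this note shows. Statements on the series, on what has been measured and on what is new or still open speak of the compounds shown alone.

Two values stand so far in a functional assay, with stated times of 30 s and 6 min, in the presence of a further agent that is not named here (on this read-out higher numbers stand for weaker inhibition and lower numbers for stronger inhibition), for this series. Compound 1 (`CCCCCCCCCCCCOc1cc(OC)c(Br)cc1C(C)=O`) gives 10600000 nM and compound 2 (`CCCCCCCCOc1cc(OC)ccc1C(C)=O`) gives 21200000 nM on that read-out. These two numbers lie within the usual scatter of each other, so compound 2 cannot be ranked apart from compound 1.

Compound 3 (`CCCCCCCCCCCCOc1cc(OC)ccc1C(C)=O`) departs from compound 2 by butyl in place of hydrogen on a saturated chain carbon, eight bonds along the chain from an oxygen on an aromatic ring and by nothing else. Among the compounds with values here, no measured pair differs in one place, so the size of this change has no direct precedent. The expectation rests only on the narrow spread of the two numbers, compound 1 at 10600000 nM and compound 2 at 21200000 nM in this assay as measured so far.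

The estimated 1.8-fold lower number from compound 2 to compound 3 (0.25 log units; within the scatter) is expected to run toward a lower number and to stay within the scatter. For compound 3 the expected value is 12000000 nM with an estimated range from 4000000 nM to 35000000 nM for the coming measurement.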

Compound 3, half-maximal inhibitory concentration: 28500000 nM
For compound 3 the middle estimate is 2.4-fold (0.38 log units) below the measured one; the range from low to high includes it.
By their numbers in this assay, from the lowest: compounds 1, 2 and 3 (each within the scatter of the next, the first and the last beyond it).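

In this assay, butyl in place of hydrogen on a saturated chain carbon, eight bonds along the chain from an oxygen on an aromatic ring, gives a 1.3-fold higher number from compound 2 to compound 3 (0.13 log units; within the scatter) and so does not separate from the scatter at this chain position. Hydrogen in place of bromo on an aromatic carbon gives a 2.7-fold higher number from compound 1 to compound 3 (0.43 log units; beyond the scatter) and is the first single change in the series to read beyond the scatter, though only as a modest step from one pair. No supporting data bear on the cause of either step.

Going by these compounds, whether a longer chain, or an amine or carboxylic acid at the chain end, would move the number beyond the scatter remains open. Also open, on these data alone, is whether chloro on that aromatic carbon, or bromo on the octyl-bearing core of compound 2, would give a step of similar size.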